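Sulfonyl to sulfanyl, with methoxy in place of bromine

The compounds below may be only part of what the source reports. "The series", "measured", "known", "first", "only" and "open" are said of these compounds alone.

Compound 1, `CCCCN(O)C(=O)Nc1cc([C@@H]2CC[C@@H](c3cc(OC)c(OC)c(OC)c3)O2)cc(OC)c1OCCSc1ccc(Br)cc1`: in a functional assay on the whole organism for inhibition, with Mus musculus as the target, at a dose of 3 mg/kg (a lower number here means less inhibition, a higher number more inhibition at the dose given (going by the name of the read-out)), compound 1 gives 11%.
Compound 2, `CCCCN(O)C(=O)Nc1cc([C@@H]2CC[C@@H](c3cc(OC)c(OC)c(OC)c3)O2)cc(OC)c1OCCSc1cccc(Br)c1`: in this assay compound 2 gives 28%.
Compound 3, `CCCCN(O)C(=O)Nc1cc([C@@H]2CC[C@@H](c3cc(OC)c(OC)c(OC)c3)O2)cc(OC)c1OCCS(=O)(=O)c1ccccc1Br`: in this assay compound 3 gives 60%.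

Compound 3 stands highest of the three numbers in this assay; compound 2 is nearest and compound 1 furthest, and both gaps lie beyond the scatter. Compound 4, `CCCCN(O)C(=O)Nc1cc([C@@H]2CC[C@@H](c3cc(OC)c(OC)c(OC)c3)O2)cc(OC)c1OCCSc1ccc(OC)cc1`, differs from compound 3 as follows: (4-methoxyphenyl)sulfanyl in place of (2-bromophenyl)sulfonyl on a saturated chain carbon, two bonds along the chain from an oxygen on an aromatic ring. For the measured compounds named here, two measured steps bear on this. Both a number 49 percentage points higher from compound 1 to compound 3 (beyond the scatter) and a number 32 percentage points higher from compound 2 to compound 3 (beyond the scatter) brought the (2-bromophenyl)sulfonyl group in together with a shift of the bromine, and both were large rises. The step to compound 4 removes that group again and installs a sulfanyl group carrying methoxy rather than bromine; the closest measured relative is compound 1, whose (4-bromophenyl)sulfanyl at the same place gave the lowest number of the set. A large fall in this assay is therefore expected, roughly undoing the earlier rise. Compound 4 is estimated at 20%, within 5% to 45%, which means an expected step of a number 40 percentage points lower from compound 3 to compound 4 (beyond the scatter).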

Compound 4, a percentage reported as inhibition, in the whole organism at one dose (the size of the read-out at that dose, not a potency): 24%
Estimate against measurement, compound 4: 4 percentage points below; the range from low to high includes it.
By their numbers in this assay, from the lowest: compound 1; then compounds 4 and 2 (each within the scatter of the next); then compound 3.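

In this assay, methoxy in place of bromo on an aromatic carbon, with the sulfanyl group kept, gives a number 13 percentage points higher from compound 1 to compound 4 (beyond the scatter) and so moves the read-out only modestly, while the change from 3-bromophenyl to 4-methoxyphenyl on a sulfur gives a number 4 percentage points lower from compound 2 to compound 4 (within the scatter) and separates nothing. For the compounds shown here, the swap of (2-bromophenyl)sulfonyl for (4-methoxyphenyl)sulfanyl gives a number 36 percentage points lower from compound 3 to compound 4 (beyond the scatter) and leaves compound 3 as the only compound well above the three sulfanyl compounds, now including one without bromine. No measurement given here accounts for any of these steps.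

The compounds shown leave open whether the high number of compound 3 belongs to the sulfonyl group or to the 2-bromophenyl group, since the two always change together in the steps to it. They also leave open how an amine or a carboxylic acid would read on the same chain.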